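The compounds below may be only part of what the source reports. "The series", "measured", "known", "first", "only" and "open" are said of these compounds alone.

The shared core, seen in compound 1 `NC(=O)N1CCN(C(=S)SCc2cn(Cc3ccc(F)cc3)nn2)CC1`, carries a 4-fluorobenzyl group and an unsubstituted urea. In a functional assay on MCF7 cells (Homo sapiens) for cytotoxicity, read by MTT assay, with a stated time of 72 h (a lower number here means a stronger inhibitor, a higher number a weaker inhibitor), compound 1 gives 22100 nM. Compound 2 `CCNC(=O)N1CCN(C(=S)SCc2cn(Cc3ccc(F)cc3)nn2)CC1` bears an ethyl on the urea nitrogen, and in this assay compound 2 gives 3660 nM. Compound 3 `CC(C)NC(=O)N1CCN(C(=S)SCc2cn(Cc3ccc(F)cc3)nn2)CC1` bears an isopropyl there, and in this assay compound 3 gives 1660 nM. Among these three numbers compound 2 stands second highest: the steps of a 6.0-fold lower number from compound 1 to compound 2 (0.78 log units; beyond the scatter) and a 2.2-fold lower number from compound 2 to compound 3 (0.34 log units; beyond the scatter) show that compound 2 sits between its two neighbours.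

Compound 4 `CCNC(=O)N1CCN(C(=S)SCc2cn(Cc3ccc(Cl)cc3)nn2)CC1` keeps the ethyl urea of compound 2 and differs only in the halogen: chloro in place of fluoro on an aromatic carbon. For the measured compounds named here, none of the measured steps, a 6.0-fold lower number from compound 1 to compound 2 (0.78 log units; beyond the scatter), a 13-fold lower number from compound 1 to compound 3 (1.12 log units; beyond the scatter) or a 2.2-fold lower number from compound 2 to compound 3 (0.34 log units; beyond the scatter), touches the halogen; all of them vary the urea substituent while the 4-fluorobenzyl is held constant. Going by the values given here, no measured step therefore bears directly on this change, and the expectation rests on the general observation that such an exchange rarely moves a number of this kind beyond the scatter. For compound 4 the step of a 1.3-fold lower number from compound 2 to compound 4 (0.10 log units; within the scatter) is expected to stay within the scatter. In this assay compound 4 is estimated at 2900 nM, with a range from 1000 nM to 8500 nM.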

Compound 4, half-maximal inhibitory concentration: > 128000 nM
Compound 4 ended at the assay's limit; the forecaster's own chance of this, stated with the estimate: 0%; middle value at least 44-fold (1.64 log units) from the limit.
By their numbers in this assay, from the lowest: compound 3; then compound 2; then compound 1. At a limit, above all of these: compound 4.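

For the compounds shown here, until now the 4-fluorobenzyl had been held constant, so this place, on an aromatic carbon of a six-membered aromatic ring of carbon only, para to a large group, had no measured step. The step of an at least 34-fold higher number from compound 2 to compound 4 (1.54 log units; beyond the scatter) shows that in this assay the place is highly sensitive to the halogen, even though one heavy atom simply replaces another and neither brings a hydrogen-bond donor or acceptor. The earlier steps at the urea all ran to lower numbers, the largest being a 13-fold lower number from compound 1 to compound 3 (1.12 log units; beyond the scatter), whereas this one runs to a higher number and is larger still; the entry for compound 4 is a limit and not a number: the limit of > 128000 nM in this assay, at which 1 of the 4 values shown sits.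

The compounds shown give no reason for the change, and they leave open whether chloro has the same outcome with the isopropyl urea of compound 3 or the unsubstituted urea of compound 1. They also leave open where hydrogen, bromo, methyl or methoxy at this place would fall relative to fluoro in compound 2 and chloro in compound 4.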